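Thiophen-2-yl swap on the compound 3 scaffold

The compounds below may be only part of what the source reports. "The series", "measured", "known", "first", "only" and "open" are said of these compounds alone.

Values in a functional assay on SK-BR-3 cells (Homo sapiens) for cytotoxicity, read by resazurin assay, with a stated time of 72 h (a higher number here means a weaker inhibitor, a lower number a stronger inhibitor), so far
- compound 1 (`OCCCSC(=S)NCc1cccnc1`) gives 1320 nM
- compound 2 (`O=C(CCSC(=S)NCc1cccnc1)NCc1ccccc1`) gives > 100000 nM
- compound 3 (`Fc1ccccc1-c1nnc(CCSC(=S)NCc2cccnc2)o1`) gives 4690 nM

Compound 2 returns only a limit of the assay (> 100000 nM) and no number. Of the two true numbers, compound 3 (4690 nM) holds the higher one, so it is the weaker of the pair. Compound 1 (1320 nM) lies lower, and that gap is beyond the scatter of repeated measurements. Among the compounds with values here, these three compounds differ in more than one place, so no single-change step is available to calibrate what follows.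

The next compound to be tested is compound 4 (`S=C(NCc1cccnc1)SCCc1nnc(-c2cccs2)o1`). It carries thiophen-2-yl in place of 2-fluorophenyl on an aromatic carbon of a five-membered aromatic ring with 2 nitrogen and 1 oxygen (thiophen-2-yl in place of 2-fluorophenyl on an aromatic carbon). The rest of the structure is unchanged from compound 3.

Within the data shown here, with no measured precedent for this swap, no clear direction is expected in this assay, and the expected step is none beyond the scatter. The estimated change (a 1.2-fold lower number from compound 3 to compound 4 (0.07 log units; within the scatter)) therefore stays small, and this expectation is anchored on compound 3 at 4690 nM as the closest measured structure. The expected value for compound 4 is 4000 nM as a central estimate, within a range of 1500 nM to 12000 nM for the coming measurement.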

Compound 4, half-maximal inhibitory concentration: 1070 nM
Compound 4: the middle estimate sits 3.7-fold (0.57 log units) above what was measured, outside the stated range (below it).
By their numbers in this assay, from the lowest: compounds 4 and 1 (each within the scatter of the next); then compound 3. At a limit, above all of these: compound 2.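

Within the data shown here, the first single-change step falls on the aromatic carbon of the five-membered aromatic ring with 2 nitrogen and 1 oxygen: in this assay, thiophen-2-yl in place of 2-fluorophenyl gives a 4.4-fold lower number from compound 3 to compound 4 (0.64 log units; beyond the scatter) and so lies beyond the scatter. Among these compounds, the aryl group at this carbon therefore affects the read-out, which the earlier compounds could not show because they differ in more than one place and offer no step to read. The swap changes a six-membered aromatic ring of carbon only to a five-membered aromatic ring with 1 hetero atom and also removes the fluorine, and nothing measured here separates these changes or accounts for the step.

A single pair cannot show whether the number follows ring size, the sulfur or the loss of fluorine, and unsubstituted phenyl, furan-2-yl or pyridin-2-yl at the same carbon would be needed to separate these. As far as these compounds go, it also remains open whether the step carries over to analogues with a longer chain in place of the present linker, or with an amine on the aryl ring.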